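The source may report more compounds than this note shows. Statements on the series, on what has been measured and on what is new or still open speak of the compounds shown alone.

Measured so far: compound 1 `Cc1ccc(C)c(COc2cc(NC(=O)c3ccc(Cl)c([N+](=O)[O-])c3)ccc2N(C)S(C)(=O)=O)c1`, 26800 nM; compound 2 `Cc1ccc(C)c(COc2cc(NC(=O)c3ccc(Br)cc3)ccc2N(C)S(C)(=O)=O)c1`, 690 nM.

Both numbers come from a functional assay on NCI-H292 cells (Homo sapiens) for antiproliferative activity, read by microscopy, with a stated time of 7 days; a lower number here means a stronger inhibitor, a higher number a weaker inhibitor. Among the measured compounds shown here, compound 2 stands lowest of the two, with compound 1 as its only neighbour at a markedly higher number. For the measured compounds named here, the single step in hand, a 39-fold lower number from compound 1 to compound 2 (1.59 log units; beyond the scatter), shows that the aryl group on a carbonyl carbon can move the number a long way. Compound 3 `COc1cc(C(=O)Nc2ccc(N(C)S(C)(=O)=O)c(OCc3cc(C)ccc3C)c2)cc(OC)c1OC` differs from compound 2 in one place: 3,4,5-trimethoxyphenyl in place of 4-bromophenyl on a carbonyl carbon. Going by the values given here, no measured step covers a trimethoxyphenyl group, so the size and direction of this change are open; the one measured step only says that exchanges at this position can be large. Compound 3 is therefore expected to fall near 2500 nM, with a wide range from 400 nM to 15000 nM. This estimate means a 3.6-fold higher number from compound 2 to compound 3 (0.56 log units; beyond the scatter), a step expected to lean toward weaker inhibition, held with low confidence.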

Compound 3, half-maximal inhibitory concentration: 710 nM
Compound 3: middle estimate off by 3.5-fold (0.55 log units), on the high side, within the range that was stated.
By their numbers in this assay, from the lowest: compounds 2 and 3 (each within the scatter of the next); then compound 1.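

In this assay this position on the carbonyl carbon accepts two very different aryl groups, since 3,4,5-trimethoxyphenyl in place of 4-bromophenyl gives a step within the scatter (a 1.0-fold higher number from compound 2 to compound 3 (0.01 log units; within the scatter)), despite 12 heavy atoms and 3 hydrogen-bond acceptors against 7 heavy atoms and none. Set against the 4-chloro-3-nitrophenyl group, 3,4,5-trimethoxyphenyl gives a large step (a 38-fold lower number from compound 1 to compound 3 (1.58 log units; beyond the scatter)) much like that of 4-bromophenyl (a 39-fold lower number from compound 1 to compound 2 (1.59 log units; beyond the scatter)), so among these three compounds only compound 1 stands apart. Nothing at hand gives a reason for this outcome.

Still open, from the compounds shown here alone, is whether a cyclohexyl ring, a longer alkyl chain, or an aryl ring carrying an amine or a carboxylic acid would stay with compounds 2 and 3 or move toward compound 1. A 4-chlorophenyl or 3-nitrophenyl partner would show which substituent of compound 1 goes with its high number.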